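The source may hold more compounds than are shown below. What is called first, only, known or untested is meant among the compounds shown, and "the series" means these compounds.

In a functional assay on MT4 cells (Homo sapiens) for cytotoxicity (on this read-out higher numbers stand for weaker inhibition and lower numbers for stronger inhibition), compound 2 `N#Cc1c(N)cccc1Sc1cccc(Cl)c1` gives 53000 nM. Compound 3 `N#Cc1c(N)cccc1Sc1ccccc1Br` gives 41000 nM, and these two numbers lie within the scatter of each other, so compound 3 is the close neighbour of compound 2 on this scale. Compound 1 `Cc1ccccc1Sc1cccc(N)c1C#N` gives > 40000 nM, which is a limit of the assay and not a number.

Compound 4 `N#Cc1c(N)cccc1Sc1cccc(N)c1` departs from compound 2 in one place: amino in place of chloro on an aromatic carbon. This puts amino in place of chloro on an aromatic carbon, meta to a large group.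

Among the measured compounds shown here, only one measured step joins two compounds that differ in a single place. That is a step that the limit leaves unreadable from compound 1 to compound 3, with bromo in place of methyl on an aromatic carbon, so it offers no size to carry over. For the measured compounds named here, no measured step covers amino in place of chloro. The expectation therefore rests on the two readable numbers, compound 2 at 53000 nM and compound 3 at 41000 nM, which sit close together. The expected change is a 1.2-fold lower number from compound 2 to compound 4 (0.07 log units; within the scatter), a step no larger than the scatter, and a report of only a limit would be no surprise. For compound 4 the estimate in this assay is 45000 nM, with an expected range from 18000 nM to 100000 nM.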

Compound 4, half-maximal inhibitory concentration: 168000 nM
Beside the measured number, compound 4's estimate is 3.7-fold (0.57 log units) below it; measured number above the stated range.
By their numbers in this assay, from the lowest: compounds 3 and 2 (each within the scatter of the next); then compound 4.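

In this assay, among the compounds shown here, the change of chloro to amino on an aromatic carbon, meta to a large group, gives the first readable step: a 3.2-fold higher number from compound 2 to compound 4 (0.50 log units; beyond the scatter). On this read-out a higher number means weaker inhibition, so the amino compound is the weaker of the pair, even though one heavy atom simply replaces another, and this place on the ring is therefore not indifferent to the group it carries. The only earlier step between compounds differing in one place could not show such an effect, because compound 1 gives a limit and not a number, which leaves its step to compound 3 unreadable: the limit of > 40000 nM in this assay, at which 1 of the 4 values shown sits.

This single step cannot tell whether the shift belongs to amino in particular, or whether a hydroxy group, a methoxy group or a carboxylic acid at the same place would move the number in the same direction and by a similar size. It also leaves open whether amino in place of chloro would have the same effect at any other place on this ring, or with a different group on the core.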